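This account rests on a few compounds, and the source may have more. Where it says the series, first, only, none or still open, it means among the compounds named here.

In an ADME assay on BaF3 cells (Mus musculus) for antiproliferative activity, read by CCK-8 assay, with a stated time of 72 h (a higher number here means a weaker inhibitor of growth, a lower number a stronger inhibitor of growth), compound 1 `O=C(CCSc1ccc2c(/C=C/c3ccccn3)n[nH]c2c1)Nc1cccc(F)c1` gives 6590 nM. Compound 2 `CN(C)c1cccc(NC(=O)CCSc2ccc3c(/C=C/c4ccccn4)n[nH]c3c2)c1` gives > 10000 nM, which is a limit of the assay and not a number. Compound 3 `O=C(CCSc1ccc2c(/C=C/c3ccccn3)n[nH]c2c1)Nc1ccc(F)c(C(F)(F)F)c1` has 4-fluoro-3-(trifluoromethyl)phenyl in place of 3-(dimethylamino)phenyl on an amide-type nitrogen. Among the measured compounds shown here, the one measured step that bears on this is an at least 1.5-fold higher number from compound 1 to compound 2 (0.18 log units; that floor lies within the scatter), with dimethylamino in place of fluoro. Since compound 3 again carries fluoro and no dimethylamino, a modest fall in the number is expected in this assay. The expected size of this change is an at least 2.0-fold lower number from compound 2 to compound 3 (0.30 log units; that floor lies within the scatter). For compound 3 the estimate is 5000 nM, with an expected range of 1800 nM to 10000 nM.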

Compound 3, concentration for 50% growth inhibition: 610 nM
Beside the measured number, compound 3's estimate is 8.2-fold (0.91 log units) above it, and the stated range ends above it.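

Among the compounds shown here, at the aryl group on the amide-type nitrogen, the earlier compounds showed no clear change, whereas 4-fluoro-3-(trifluoromethyl)phenyl in place of 3-fluorophenyl gives a clear gain in this assay: an 11-fold lower number from compound 1 to compound 3 (1.03 log units; beyond the scatter). Against 3-(dimethylamino)phenyl, the change reads an at least 16-fold lower number from compound 2 to compound 3 (1.21 log units; beyond the scatter). That step is only a floor, because compound 2 stands at a limit of the assay and not at a number: the limit of > 10000 nM in this assay, at which 1 of the 3 values shown sits.

Which part of the 4-fluoro-3-(trifluoromethyl)phenyl group carries the gain stays open. A 3-(trifluoromethyl)phenyl group or a ring bearing a nitrile would help to separate the parts.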